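A few compounds are considered here, and "the series" means these few. Any claim that something is new, unique, unknown or untested is made for them only; others in the source may bear on it.

In a functional assay on the whole organism (brain) with Mus musculus as the target (a higher number here means that more compound is needed for the effect, a lower number that less compound is needed), compound 1 `O=[N+]([O-])c1ccc(SCCc2c[nH]cn2)nc1` gives 2.6 mg/kg and compound 2 `O=[N+]([O-])c1cccc(OCCc2c[nH]cn2)c1` gives 0.9 mg/kg. These two compounds differ from each other in more than one place, so their values offer only a rough frame for the series.

Compound 3 `COC(=O)c1ccc(OCCc2c[nH]cn2)cc1` has no exact number, only the limit of > 3 mg/kg. This result is a limit of the assay and not a measured dose, so compound 3 cannot be placed exactly against the other two.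

Compound 4 `O=C(c1ccccc1)c1ccc(OCCc2c[nH]cn2)cc1` keeps the core of compound 3 and carries phenyl in place of methoxy on a carbonyl carbon. Among the compounds with values here, no measured pair in this small set shows what this exchange does in this assay, so the expectation is broad. It leans on the numbers that were obtained, with compound 1 at 2.6 mg/kg and compound 2 at 0.9 mg/kg. The estimated step of an at least 2.0-fold lower number from compound 3 to compound 4 (0.30 log units; that floor lies within the scatter) points modestly toward a lower dose, although its true size remains uncertain since it starts from a limit. Another limit result would not be surprising. For compound 4 the expected dose is 1.5 mg/kg, with an estimated range from 0.4 mg/kg to 5 mg/kg.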

Compound 4, dose for half-maximal effect: 2.6 mg/kg
For compound 4 the middle estimate is 1.7-fold (0.24 log units) below the measured one; the range from low to high includes it.
By their numbers in this assay, from the lowest: compound 2; then compounds 1 and 4 (each within the scatter of the next). At a limit, above all of these: compound 3.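

With phenyl in place of methoxy on a carbonyl carbon, the series gains a measured dose where only a limit stood before, and in this assay the step reads as follows (an at least 1.1-fold lower number from compound 3 to compound 4 (0.06 log units; that floor lies within the scatter)). Compound 3 has > 3 mg/kg as its result, and that is a limit of the assay and not a number. The floor of this step lies within the scatter, so the change is not shown to lower the dose, and its true size cannot be fixed because the step starts from a limit: (the limit of > 3 mg/kg in this assay, at which 1 of the 4 values shown sits).

Going by these compounds, it remains open whether an amine or a carboxylic acid on that carbonyl carbon would give a measured dose, and whether a longer chain in place of methoxy would fall on the side of compound 3 or of compound 4. All other pairs here differ in more than one place, so their steps cannot be read, and what the phenyl group does on a core like that of compound 2 also stays unsettled.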